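Swapping the Imidazole for an Aminopyridazine

The source may report more compounds than this note shows. Statements on the series, on what has been measured and on what is new or still open speak of the compounds shown alone.

Measured so far in a physicochemical assay for lipophilicity; a lower number here means a more polar compound, a higher number a more lipophilic compound:
- compound 1 `Cc1cc(C)c(-c2ncc[nH]2)cc1NC(=O)c1ccc(OCc2ccccn2)cc1`: 3.1
- compound 2 `Cc1cc(C)c(-c2cn(C)cn2)cc1NC(=O)c1ccc(OCc2ccccn2)cc1`: 3
- compound 3 `Cc1cc(C)c(-c2nc3ccccc3[nH]2)cc1NC(=O)c1ccc(OCc2ccccn2)cc1`: > 3.5

Three compounds share one core and differ only in the ring attached to one aromatic carbon. Compound 1 and compound 2 sit close together, a number 0.10 log units lower from compound 1 to compound 2 (within the scatter). For compound 3 the value > 3.5 is a limit of the assay, not a number. Against these two numbers compound 1 is the one with the 1H-imidazol-2-yl group, and the move to 1-methyl-1H-imidazol-4-yl changed nothing beyond the scatter.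

Compound 4 `Cc1cc(C)c(-c2ccc(N)nn2)cc1NC(=O)c1ccc(OCc2ccccn2)cc1` changes the same position: 6-aminopyridazin-3-yl in place of 1H-imidazol-2-yl on an aromatic carbon.

Within the data shown here, two measured steps touch this position. The step of a number 0.10 log units lower from compound 1 to compound 2 (within the scatter) kept the five-membered ring and left the number where it was. The step of a number at least 0.40 log units higher from compound 1 to compound 3 (beyond the scatter) enlarged the ring system and pushed the value to the limit (the limit of > 3.5 in this assay, at which 1 of the 3 values shown sits). Neither step introduces a six-membered ring carrying an amino group, so the closest guide is the size of these shifts rather than their direction.

Compound 4 is expected to come out lower, with an estimated step of a number 0.70 log units lower from compound 1 to compound 4 (beyond the scatter). The value of compound 4 in this assay is estimated at 2.4, within a range from 1.8 to 3.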

Compound 4, distribution coefficient: 2.6
Estimate against measurement, compound 4: 0.20 log units below; the range from low to high includes it.
By their numbers in this assay, from the lowest: compound 4; then compounds 2 and 1 (each within the scatter of the next). At a limit, above all of these: compound 3.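

In this assay, this position had so far shown only a shift within the scatter and a rise to a limit, and 6-aminopyridazin-3-yl now gives the first clear fall: a number 0.50 log units lower from compound 1 to compound 4 (beyond the scatter), and likewise a number 0.40 log units lower from compound 2 to compound 4 (beyond the scatter). Both compound 3 and compound 4 carry a larger group than the 1H-imidazol-2-yl of compound 1, yet they go opposite ways, so a larger group at this aromatic carbon does not by itself set the direction of the change, as a number at least 0.90 log units lower from compound 3 to compound 4 (beyond the scatter) shows. The value for compound 3 is a limit of the assay and not a number, so that last step has no fixed size: the limit of > 3.5 in this assay, at which 1 of the 4 values shown sits.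

The change swaps a five-membered ring for a six-membered one and adds an amino group in a single move, so the compounds shown cannot tell which of the two carries the fall. A plain pyridazin-3-yl ring without the amine, or a 6-methoxypyridazin-3-yl ring with a methoxy group in its place, would separate those two parts of the change.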